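Chain-end swap in the compound 1 series

A few compounds are considered here, and "the series" means these few. Any claim that something is new, unique, unknown or untested is made for them only; others in the source may bear on it.

Values in a functional assay for inhibition, with Homo sapiens as the target; a higher number here means a weaker inhibitor, a lower number a stronger inhibitor:
- compound 1 `O=C(O)CSCCCCCCn1nc(-c2ccccc2)c(-c2ccccc2)c1-c1ccccc1`: 870 nM
- compound 2 `O=C(O)C[S+]([O-])CCCCCCn1nc(-c2ccccc2)c(-c2ccccc2)c1-c1ccccc1`: 6500 nM

Compound 2 holds the higher of the two numbers. Compound 3 `c1ccc(-c2nn(CCCCCCCCc3nnn[nH]3)c(-c3ccccc3)c2-c2ccccc2)cc1` differs from it by a group of 7 heavy atoms (3 carbon, 4 nitrogen; one five-membered aromatic ring with 4 hetero atoms) in place of a group of 6 heavy atoms (2 carbon, 3 oxygen, 1 sulfur; no ring), on a saturated chain carbon, six bonds along the chain from an aromatic nitrogen. Among the measured compounds shown here, the only measured step, a 7.5-fold higher number from compound 1 to compound 2 (0.87 log units; beyond the scatter), is modest and sits at the same chain end. For the measured compounds named here, it is the sole guide, and no measured compound carries the 2-(1H-tetrazol-5-yl)ethyl group. Compound 3 also has no sulfur, so a return toward compound 1 is expected, with low confidence. The expected change in this assay is a 3.3-fold lower number from compound 2 to compound 3 (0.51 log units; beyond the scatter). The estimated value for compound 3 is 2000 nM, with an expected range of 400 nM to 10000 nM.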

Compound 3, half-maximal inhibitory concentration: 1040 nM
Beside the measured number, compound 3's estimate is 1.9-fold (0.28 log units) above it; the measured number falls inside the stated range.
By their numbers in this assay, from the lowest: compounds 1 and 3 (each within the scatter of the next); then compound 2.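

In this assay, 2-(1H-tetrazol-5-yl)ethyl at this chain end recovers what the group of compound 2 gave up (a 6.3-fold lower number from compound 2 to compound 3 (0.80 log units; beyond the scatter)). Set against (carboxymethyl)sulfanyl, it shows no change beyond the scatter (a 1.2-fold higher number from compound 1 to compound 3 (0.08 log units; within the scatter)), so this position accepts a sulfur-free chain end carrying an aromatic ring. Nothing further is available to explain these numbers.
Still open, on these data alone, is whether a plain carboxylic acid without sulfur, an amine or a longer chain at this position would match compound 3. Also open, as far as these compounds go, is whether the 2-(1H-tetrazol-5-yl)ethyl result holds on a different core.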